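Step from compound 2 to compound 3 in the series

The compounds below may be only part of what the source reports. "The series", "measured", "known", "first", "only" and "open" are said of these compounds alone.

For the measured compounds named here, compound 2 `O=Cc1ccc(-c2cn3ccnc3c(-c3ccc4ncn(C5CCCCC5)c4c3)n2)cc1` stands lowest of the two numbers so far in a functional assay on KM12 cells (Homo sapiens) for inhibition, read by sulforhodamine B assay, with a stated time of 48 h, tested at 10 uM (a lower number here means less inhibition, a higher number more inhibition at the concentration tested (going by the name of the read-out)), giving 3.69%. Going by the values given here, its nearest neighbour is compound 1 `COc1ccc(-c2cn3ccnc3c(-c3ccc4ncn(C5CCCCC5)c4c3)n2)cc1`, which in this assay gives 83.2%; the one measured step, a number 79.5 percentage points lower from compound 1 to compound 2 (beyond the scatter), covers formyl in place of methoxy on an aromatic carbon. Compound 3 `c1ccc2c(-c3cn4ccnc4c(-c4ccc5ncn(C6CCCCC6)c5c4)n3)cccc2c1` is not yet measured; it differs from compound 2 by naphthalen-1-yl in place of 4-formylphenyl on an aromatic carbon. Among the compounds with values here, that step bears on the measured one only in part: the formyl group leaves, and the step of a number 79.5 percentage points lower from compound 1 to compound 2 (beyond the scatter) suggests that its loss could restore much of the inhibition, but no measured compound carries naphthalen-1-yl, so a large rise is expected with wide uncertainty. For compound 3 the estimated step is a number 41.3 percentage points higher from compound 2 to compound 3 (beyond the scatter). Compound 3 is expected to give about 45% in this assay, within 5% to 85%.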

Compound 3, a percentage reported as inhibition, at one concentration (the size of the read-out at that concentration, not a potency): 11.1%
Compound 3: middle estimate off by 33.9 percentage points, on the high side; measured number inside the range.
By their numbers in this assay, from the lowest: compounds 2 and 3 (each within the scatter of the next); then compound 1.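

In this assay, the change at this aromatic carbon gives a number 7.4 percentage points higher from compound 2 to compound 3 (within the scatter), so removing the formyl group does not by itself bring the inhibition back. Naphthalen-1-yl in place of 4-methoxyphenyl gives a number 72.1 percentage points lower from compound 1 to compound 3 (beyond the scatter), so two different replacements of the 4-methoxyphenyl group on the same core now both stand far from compound 1, and the low number of compound 2 is no longer a finding about formyl alone. No measurement is available that explains these differences.

From the compounds shown here alone, whether the methoxy group itself carries the inhibition remains open, as a plain phenyl, or a phenyl bearing a hydroxyl group or an amine, at this carbon could separate the methoxy group from the ring that holds it. Also open, going by these compounds, is how far the inhibition of compound 1 depends on the cyclohexyl group, which a shorter chain such as ethyl could test.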